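Carbamate side chain series: removing the methoxy group

The source may report more compounds than this note shows. Statements on the series, on what has been measured and on what is new or still open speak of the compounds shown alone.

Measured so far in a functional assay on L1210 cells (Mus musculus), with a stated time of 12 days; a higher number here means a more potent compound, by a factor of ten per unit of this negative logarithm, a lower number a less potent compound:
compound 1, `CCCC1=C(N2CC2)C(=O)C(C(COC(N)=O)OC)=C(N2CC2)C1=O`: 5.07
compound 2, `CCC1=C(N2CC2)C(=O)C(C(COC(N)=O)OC)=C(N2CC2)C1=O`: 5.22

Among the measured compounds shown here, compound 2 gives the larger of the two numbers, but compound 2 and compound 1 sit within the scatter of each other: the only measured step, a number 0.15 log units higher from compound 1 to compound 2 (within the scatter), concerns hydrogen in place of methyl on a saturated chain carbon, two bonds along the chain from a double-bonded ring carbon, and is no change to build on.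

Compound 3, `CCC1=C(N2CC2)C(=O)C(CCOC(N)=O)=C(N2CC2)C1=O`, is not yet measured. It differs from compound 2 by hydrogen in place of methoxy on a saturated chain carbon bound to a double-bonded ring carbon and a saturated chain carbon. For the measured compounds named here, no measured step touches the methoxy or the saturated chain carbon bound to a double-bonded ring carbon and a saturated chain carbon; the one step known, between compound 1 and compound 2, was within the scatter and lies at another place. The expected step of a number 0.12 log units lower from compound 2 to compound 3 (within the scatter) for compound 3 is therefore small and of uncertain direction. In this assay compound 3 is estimated at 5.1, with a range from 4.5 to 5.7.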

Compound 3, logarithm of the reciprocal of the active concentration, log(1/C): 5.48
For compound 3 the middle estimate is 0.38 log units below the measured one, and the stated range covers the measured number.
By their numbers in this assay, from the lowest: compounds 1, 2 and 3 (each within the scatter of the next, the first and the last beyond it).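

In this assay, among the compounds shown here, the replacement of methoxy by hydrogen on a saturated chain carbon bound to a double-bonded ring carbon and a saturated chain carbon gives a number 0.26 log units higher from compound 2 to compound 3 (within the scatter) and is the first reading at this position, since the earlier step lay elsewhere on the chain. The methoxy, with its 2 heavy atoms and 1 hydrogen-bond acceptor, can therefore be removed from the core of compound 2 without a loss of potency beyond the scatter, so compound 3 shows that this group is not required for activity at this level in this cell assay. No measurement shown bears on the reason for the size of this step.

Still open, on these data alone, is whether another group on this same carbon, such as a hydroxyl, an amine or an ethoxy, would move the number beyond the scatter of compound 3. Also open, as far as these compounds go, is whether removing the methoxy gives a similar step on the longer chain carried by compound 1, and how a carboxylic acid in place of the carbamate would read.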